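Amine substituent change on the shared core

The compounds below may be only part of what the source reports. "The series", "measured", "known", "first", "only" and "open" are said of these compounds alone.

Compound 1 `O=S(=O)(NCC1CCN(CCCc2c[nH]c3ccc(-n4cnnc4)cc23)CC1)c1ccccc1` gives 60 nM in an assay on CHO cells for displacement of a labelled ligand from 5-hydroxytryptamine receptor 1B (Homo sapiens); on this read-out lower numbers stand for stronger inhibition and higher numbers for weaker inhibition. Compound 2 `c1ccc2c(c1)CCC2NCC1CCN(CCCc2c[nH]c3ccc(-n4cnnc4)cc23)CC1` gives 25 nM in this assay, and the step of a 2.4-fold lower number from compound 1 to compound 2 (0.38 log units; beyond the scatter) leaves compound 2 with the lowest number of the two measured. Compound 3 `CC(=O)Nc1ccc([C@@H](C)NCC2CCN(CCCc3c[nH]c4ccc(-n5cnnc5)cc34)CC2)cc1` carries the change (1-(4-acetamidophenyl)ethyl in place of 2,3-dihydro-1H-inden-1-yl on an amine nitrogen). Among the compounds with values here, the only measured step concerns the same amine nitrogen and was modest, so a shift of roughly comparable size, in either direction or none beyond the scatter, is expected for compound 3 in this assay. The estimate for compound 3 is 40 nM, between 12 nM and 130 nM. That estimate corresponds to an expected step of a 1.6-fold higher number from compound 2 to compound 3 (0.20 log units; within the scatter).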

Compound 3, half-maximal inhibitory concentration: 8.9 nM
The estimate for compound 3 lay 4.5-fold (0.65 log units) above the measured number; the measured number lies below the stated range.
By their numbers in this assay, from the lowest: compound 3; then compound 2; then compound 1.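

On the amine nitrogen, 1-(4-acetamidophenyl)ethyl in place of 2,3-dihydro-1H-inden-1-yl gives a 2.8-fold lower number from compound 2 to compound 3 (0.45 log units; beyond the scatter) in this assay and leaves compound 3 with the lowest number, so the larger group with an amide is accepted at this position. Against phenylsulfonyl, the same group gives a 6.7-fold lower number from compound 1 to compound 3 (0.83 log units; beyond the scatter) and opens the widest gap among the three compounds. No evidence on hand accounts for this gain.

On these data alone, it remains open whether the acetamido group, the methyl branch or the defined stereocentre carries the gain. A plain 1-phenylethyl group, its opposite stereoisomer or a 4-aminophenyl analogue would separate these contributions.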